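This account rests on a few compounds, and the source may have more. Where it says the series, first, only, none or still open, it means among the compounds named here.

Working notes on the series, read in a toxicity assay on HUVEC cells (Homo sapiens) for cytotoxicity, read by MTT assay, with a stated time of 96 h; on this read-out lower numbers stand for stronger inhibition and higher numbers for weaker inhibition. Compound 1 (`O=C1NC(=O)/C(=C\c2ccc(OCC(=O)N3N=C(c4ccccc4)CC3c3ccc(Cl)c(Cl)c3)cc2)S1`) gives > 10000 nM, and this is a limit of the assay, not a number. Compound 2 (`O=C1NC(=O)/C(=C\c2ccc(OCC(=O)N3N=C(c4ccc(F)cc4)CC3c3ccco3)cc2)S1`) gives a true number, 700 nM. Among the measured compounds shown here, with two compounds there is little to go on: the limit of > 10000 nM in this assay, at which 1 of the 2 values shown sits, is the main fact about where the series stands, and no step between measured compounds is available to calibrate the size of a single change.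

Compound 3 (`O=C1NC(=O)/C(=C\c2ccc(OCC(=O)N3N=C(c4ccc(F)cc4)CC3c3ccc(Cl)c(Cl)c3)cc2)S1`) comes from compound 1 by one edit, (fluoro in place of hydrogen on an aromatic carbon), which turns phenyl into 4-fluorophenyl, with fluoro in place of hydrogen on an aromatic carbon. The rest of compound 1 stays as it is.

For this edit, the expectation in this assay is no step beyond the usual scatter, and no firm direction can be assigned. Compound 3 may well stay at the limit too, which is expected about as often as not. The estimated change is a number no higher from compound 1 to compound 3 (the limit leaves the size open). For compound 3 the expected value is 10000 nM, with an estimated range of 3000 nM to 30000 nM.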

Compound 3, half-maximal inhibitory concentration: 2000 nM
Compound 3: the middle estimate sits 5.0-fold (0.70 log units) above what was measured; the measured number lies below the stated range.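

In this assay, fluoro in place of hydrogen on an aromatic carbon, para to a large group, is enough to bring the 3,4-dichlorophenyl compounds off the limit, with an at least 5.0-fold lower number from compound 1 to compound 3 (0.69 log units; beyond the scatter). Compound 3 also gives the series its first comparison at the saturated ring carbon with 4-fluorophenyl held constant: 3,4-dichlorophenyl in place of furan-2-yl gives a 2.9-fold higher number from compound 2 to compound 3 (0.46 log units; beyond the scatter), so furan-2-yl carries the lower number of the two at that position. The step from the phenyl compound has a size open on one side, since compound 1 stands at a limit of the assay and not at a number: the limit of > 10000 nM in this assay, at which 1 of the 3 values shown sits.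

The compounds shown leave open whether the fluoro step holds with furan-2-yl on the saturated ring carbon, as only the 3,4-dichlorophenyl pair reads it. They also leave open whether the effect belongs to fluoro itself or would appear with chloro, methoxy or a dimethylamino group at the same place on the ring.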